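Notes on ring substitution in a small biaryl amine series

The compounds below may be only part of what the source reports. "The series", "measured", "known", "first", "only" and "open" are said of these compounds alone.

Measured so far:
- compound 1 `Oc1ccccc1CNc1ccc(-c2ccc(F)cc2)cc1` gives 3860 nM in a functional assay on Jurkat cells (Homo sapiens) for activation, with a stated time of 24 h; on this read-out higher numbers stand for an effect only at larger amounts of compound and lower numbers for an effect already at smaller amounts
- compound 2 `Oc1ccccc1CNc1ccc(-c2cccc(F)c2)cc1` gives 2020 nM in this assay

Compound 2 has the lowest of the two numbers in this assay; its nearest neighbour is compound 1, and the step of a 1.9-fold lower number from compound 1 to compound 2 (0.28 log units; within the scatter) lies within the scatter. Compound 3 `Oc1ccccc1CNc1ccc(-c2ccccc2Cl)cc1` is not yet measured in this assay. Its change from compound 2 is 2-chlorophenyl in place of 3-fluorophenyl on an aromatic carbon. Within the data shown here, no measured step covers this exchange; the one step known, a 1.9-fold lower number from compound 1 to compound 2 (0.28 log units; within the scatter), moves a fluorine within the same ring and stays within the scatter. On that basis no step beyond the scatter is expected for compound 3, so the estimated step of a 1.2-fold higher number from compound 2 to compound 3 (0.09 log units; within the scatter) is small. Compound 3 is therefore estimated at 2500 nM in this assay, with a range from 800 nM to 8000 nM.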

Compound 3, half-maximal effective concentration: "not active" (no number reported)
Compound 3 has no reported number here, so the estimate cannot be set against anything.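

Among these compounds, compound 3 is reported as "not active" without a number in this assay, so no step from compound 2 can be read. Nothing shown bears on this result. The compounds shown leave open whether the halogen or its ring position matters.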